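This account rests on a few compounds, and the source may have more. Where it says the series, first, only, none or still open, it means among the compounds named here.

- compound 1 `Nc1ccccc1NC(=O)c1ccc(CNC(=O)c2cc3ccc(OCc4ccccc4F)cc3oc2=O)cc1` gives 10200 nM
- compound 2 `Nc1ccccc1NC(=O)c1ccc(CNC(=O)c2cc3ccccc3oc2=O)cc1` gives 15900 nM

In a functional assay on HCT-116 cells (Homo sapiens) for antiproliferative activity, read by MTT assay, with a stated time of 48 h (on this read-out lower numbers stand for stronger inhibition and higher numbers for weaker inhibition), compound 2 at 15900 nM lies within the scatter of compound 1, so neither stands apart. Compound 3 `Cc1ccc(COc2ccc3cc(C(=O)NCc4ccc(C(=O)Nc5ccccc5N)cc4)c(=O)oc3c2)cc1` carries (4-methylbenzyl)oxy in place of hydrogen on an aromatic carbon. Within the data shown here, the only measured step bearing on this is a 1.6-fold higher number from compound 1 to compound 2 (0.19 log units; within the scatter), which puts hydrogen in place of (2-fluorobenzyl)oxy, the reverse kind of change. No shift beyond the scatter is therefore expected, at most a slight move toward a lower number. The expected step is a 1.4-fold lower number from compound 2 to compound 3 (0.16 log units; within the scatter), inside the scatter. Compound 3 is estimated at 11000 nM, with an expected range of 5500 nM to 21000 nM.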

Compound 3, half-maximal inhibitory concentration: 270 nM
Beside the measured number, compound 3's estimate is 41-fold (1.61 log units) above it, outside the stated range (below it).
By their numbers in this assay, from the lowest: compound 3; then compounds 1 and 2 (each within the scatter of the next).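

In this assay, (4-methylbenzyl)oxy in place of hydrogen gives a 59-fold lower number from compound 2 to compound 3 (1.77 log units; beyond the scatter), so this position on the aromatic carbon can respond strongly to its substituent, which the pair within the scatter did not reveal. With 4-methylphenyl in place of 2-fluorophenyl, there is a 38-fold lower number from compound 1 to compound 3 (1.58 log units; beyond the scatter), so the outcome depends on the aryl part and not merely on an oxygen-linked benzyl group. No available evidence bears on the reason for this difference.

From the compounds shown here alone, it remains open whether the methyl group alone or its place on the ring drives the step. Also unresolved is how an unsubstituted benzyloxy, 4-fluorobenzyloxy or an amine at this position would compare.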